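The source may hold more compounds than are shown below. What is called first, only, known or untested is meant among the compounds shown, and "the series" means these compounds.

Measured compounds in a functional assay on HT-29 cells (Homo sapiens) for antiproliferative activity, read by sulforhodamine B assay, with a stated time of 48 h; on this read-out lower numbers stand for stronger inhibition and higher numbers for weaker inhibition:

compound 1 `CCCCc1ccc(NS(=O)(=O)c2ccc(N3CCNC3=O)cc2)cc1`: 610 nM
compound 2 `O=C1NCCN1c1ccc(S(=O)(=O)Nc2cccc(Br)c2)cc1`: 77 nM
compound 3 `COc1ccc(NS(=O)(=O)c2ccc(N3CCNC3=O)cc2)cc1OC`: 520 nM

Compound 1 has the highest number of the three in this assay. Its nearest neighbour is compound 3, whose number lies within the usual scatter of compound 1, so no order between the two can be claimed. Compound 2 stands apart: its number is lower than that of compound 1 by a margin beyond the scatter, and it also carries the lowest number of the set. Among the measured compounds shown here, no pair of measured compounds differs in a single place, so no measured step is available.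

The next compound, compound 4 `CC(C)Cc1ccc(NS(=O)(=O)c2ccc(N3CCNC3=O)cc2)cc1`, has not yet been measured in this assay. It is related to compound 1 by isopropyl in place of propyl on a saturated chain carbon bound to an aromatic carbon. The two share every atom and differ only in how the chain is joined. Nothing in the measured set speaks to a change of this kind, so the step in this assay is expected to be small, in either direction, and not beyond the scatter. The expected step is a 1.1-fold lower number from compound 1 to compound 4 (0.04 log units; within the scatter). Compound 4 is therefore estimated at 560 nM, with a range from 250 nM to 1300 nM.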

Compound 4, half-maximal inhibitory concentration: > 1000 nM
Compound 4 was reported as a limit; the forecaster's own chance of this, stated with the estimate: 3%; middle value at least 1.7-fold (0.25 log units) away from the limit.
By their numbers in this assay, from the lowest: compound 2; then compounds 3 and 1 (each within the scatter of the next). At a limit, above all of these: compound 4.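

In this assay, among the compounds shown here, compounds 1 and 4 give the first reading of the series that turns on a single place: isopropyl in place of propyl on a saturated chain carbon bound to an aromatic carbon, which, cut one bond further out, reads as butyl to isobutyl. The step is an at least 1.6-fold higher number from compound 1 to compound 4 (0.21 log units; that floor lies within the scatter), so this rearrangement of the same atoms is not shown to leave the read-out unchanged, but its floor alone does not establish a difference beyond the usual scatter. Compound 4 is reported only as a limit of the assay: the limit of > 1000 nM in this assay, at which 1 of the 4 values shown sits.

On these data alone, the true size of the step stays open, and the pair cannot say whether the two chains differ by little or by much. Also open, as far as these compounds go, is how a tert-butyl group, a longer chain such as hexyl, or an amine or carboxylic acid at the end of the chain would read at this place, and one pair of isomeric chains fixes no trend for any of them.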